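The source may report more compounds than this note shows. Statements on the series, on what has been measured and on what is new or still open speak of the compounds shown alone.

Among the measured compounds shown here, in a functional assay on A549 cells (Homo sapiens) for inhibition, read by sulforhodamine B assay, with a stated time of 48 h, tested at 50 uM (a higher number here means more inhibition of growth at the concentration tested, a lower number less inhibition of growth), compound 2 `COc1ccc([C@@H]2C/C(=N/OCc3cn(-c4ccccc4CO)nn3)c3cc(CC=C(C)C)c(OC)cc3O2)cc1` gives 100%, the higher of the two numbers so far, while compound 1 `COc1ccc([C@@H]2C/C(=N/OCc3cn(-c4ccc(C#N)cc4)nn3)c3cc(CC=C(C)C)c(OC)cc3O2)cc1` gives 42%. Compound 3 `COc1ccc([C@@H]2C/C(=N/OCc3cn(-c4cc(OC)c(OC)c(OC)c4)nn3)c3cc(CC=C(C)C)c(OC)cc3O2)cc1` has 3,4,5-trimethoxyphenyl in place of 2-(hydroxymethyl)phenyl on an aromatic nitrogen. For the measured compounds named here, only one measured step bears on this change. That step, a number 58 percentage points higher from compound 1 to compound 2 (beyond the scatter), is large and changes the group at this same place, so swapping this group can clearly shift the number. Like compound 1, compound 3 lacks the 2-(hydroxymethyl)phenyl group, so a sizeable fall is expected, estimated as a number 35 percentage points lower from compound 2 to compound 3 (beyond the scatter). For compound 3 the expected value is 65%, within an estimated range of 35% to 100%.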

Compound 3, percent growth inhibition at one concentration: 28%
Beside the measured number, compound 3's estimate is 37 percentage points above it; the whole stated range lies above it.
By their numbers in this assay, from the lowest: compound 3; then compound 1; then compound 2.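

In this assay, a second ring without the hydroxymethyl group also falls far short of compound 2, with a number 72 percentage points lower from compound 2 to compound 3 (beyond the scatter). Swapping one such ring for another still moves the number, with a number 14 percentage points lower from compound 1 to compound 3 (beyond the scatter), so the two replacements are not equivalent, and the ring with more oxygen atoms does not recover the loss. Nothing available explains why these numbers differ. Still open, on these data alone, is whether a plain phenyl, or a phenyl bearing an amine or a carboxylic acid in place of the hydroxymethyl, would stay near compound 2 or drop toward compound 3.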